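Azole replacement on the shared core: expectation for compound 3

The source may hold more compounds than are shown below. What is called first, only, known or untested is meant among the compounds shown, and "the series" means these compounds.

Compound 2 `c1ccc(-c2nc[nH]n2)c(NCC2=NCCN2)c1` stands highest of the two numbers in a functional assay with Alpha-1B adrenergic receptor (Homo sapiens) as the target, read by calcium flux (on this read-out lower numbers stand for smaller maximal responses and higher numbers for larger maximal responses), where compound 2 gives 100%. Its nearest neighbour, compound 1 `CC(C)n1ncnc1-c1ccccc1NCC1=NCCN1`, gives 0% in this assay, a gap beyond the scatter. Compound 3 `Cn1ccc(-c2ccccc2NCC2=NCCN2)n1` is not yet measured in this assay. Relative to compound 2 the change is 1-methyl-1H-pyrazol-3-yl in place of 1H-1,2,4-triazol-3-yl on an aromatic carbon. For the measured compounds named here, no step between measured compounds that differ in one place is available, so the size of this step is not anchored by a precedent. Given that compound 1, the only other compound with a number, gives 0%, a downward step of substantial size is expected. The two known values in this assay span the full range of the read-out. Compound 3 is therefore expected to give 30% in this assay, with a range from 0% to 80%, meaning an estimated step of a number 70 percentage points lower from compound 2 to compound 3 (beyond the scatter).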

Compound 3, largest response reached (reported as maximal response), in percent of the reference or control that the assay uses: 33%
The estimate for compound 3 lay 3 percentage points below the measured number; the measured number falls inside the stated range.
By their numbers in this assay, from the lowest: compound 1; then compound 3; then compound 2.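

In this assay, for the compounds shown here, this is the one step so far that isolates a single place on the shared core: 1-methyl-1H-pyrazol-3-yl in place of 1H-1,2,4-triazol-3-yl on the aromatic carbon gives a number 67 percentage points lower from compound 2 to compound 3 (beyond the scatter) as a large change. The maximal response at this position therefore depends strongly on the identity of the azole, although compound 3 still gives 33% in this assay rather than losing the response entirely. No available data bear on the reason for this step.

The change alters the ring hetero atoms, the hydrogen-bond donor count and the heavy atom count together, so these contributions remain unseparated. The unmethylated 1H-pyrazol-3-yl and 1-methyl-1H-1,2,4-triazol-3-yl groups at the same aromatic carbon would each divide this step into smaller parts.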